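A Methylcarbamoyl Swap on the Sulfur-Bound Chain of Compound 1

The compounds below may be only part of what the source reports. "The series", "measured", "known", "first", "only" and "open" are said of these compounds alone.

Measured so far:
compound 1 `N#Cc1c(N)nc(SCc2nnn[nH]2)c(C#N)c1-c1ccc(OCC2CC2)cc1`: 1%
compound 2 `CCOc1ccc(-c2c(C#N)c(N)nc(SCC(N)=O)c2C#N)cc1`: 20%
compound 3 `C=CCOc1ccc(-c2c(C#N)c(N)nc(SCc3ccn[nH]3)c2C#N)cc1`: 13%

These values come from an assay on CHO cells for displacement of a labelled ligand from adenosine receptor A3 (Homo sapiens), read by scintillation counting, with a stated time of 120 min, tested at 1 uM; on this read-out lower numbers stand for less inhibition and higher numbers for more inhibition at the one concentration tested (going by the name of the read-out). Compound 1 stands lowest of the three; compound 3 lies nearest to it and compound 2 furthest, both gaps beyond the usual scatter. Among the measured compounds shown here, no step between two measured compounds differing in one place exists, so compound 4 `CNC(=O)CSc1nc(N)c(C#N)c(-c2ccc(OCC3CC3)cc2)c1C#N` is approached through its difference from compound 1: methylcarbamoyl in place of 1H-tetrazol-5-yl on a saturated chain carbon bound to a sulfur. Compound 2, with 20%, shows that this set can reach clearly higher inhibition than compound 1. For compound 4 a modest rise is expected, a number 11 percentage points higher from compound 1 to compound 4 (beyond the scatter), since compound 1 gives only 1%. Compound 4 is estimated at 12%, within 2% to 30%.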

Compound 4, a percentage reported as inhibition, at one concentration (the size of the read-out at that concentration, not a potency): 3%
Estimate against measurement, compound 4: 9 percentage points above; measured number inside the range.
By their numbers in this assay, from the lowest: compounds 1, 4, 3 and 2 (each within the scatter of the next, the first and the last beyond it).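

In this assay, methylcarbamoyl in place of 1H-tetrazol-5-yl on a saturated chain carbon bound to a sulfur gives a number 2 percentage points higher from compound 1 to compound 4 (within the scatter). On the core of compound 1, then, an open group with no ring reads the same as the five-membered aromatic ring within the scatter, and the ring is not needed for this reading. Nothing available explains this result. Still open, going by these compounds, is whether a carboxylic acid or an amine in this place would read differently on the same core.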